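Swapping methoxyphenyl for chlorophenyl on compound 2

The source may report more compounds than this note shows. Statements on the series, on what has been measured and on what is new or still open speak of the compounds shown alone.

Compound 1 `Fc1cccc(-c2nc(Nc3ccccc3)c3ccccc3n2)c1`: > 50000 nM
Compound 2 `COc1ccccc1Nc1nc(-c2cccc(F)c2)nc2ccc(F)cc12`: > 50000 nM
Compound 3 `Fc1cccc(-c2nc(Nc3ccc(Cl)cc3)c3cc(F)ccc3n2)c1`: 32600 nM
Compound 4 `Fc1cccc(-c2nc(Nc3cccc(Cl)c3)c3cc(F)ccc3n2)c1`: not yet measured

In a functional assay on COLO 205 cells (Homo sapiens) for cytotoxicity, read by MTT assay, with a stated time of 48 h (on this read-out lower numbers stand for stronger inhibition and higher numbers for weaker inhibition), compound 2 gives only a limit, > 50000 nM. Compound 1 likewise sits at a limit, > 50000 nM. Compound 3 gives a number, 32600 nM. The change from compound 2 to compound 4 is 3-chlorophenyl in place of 2-methoxyphenyl on a nitrogen on an aromatic ring. Among the compounds with values here, the only measured step that bears on it is an at least 1.5-fold lower number from compound 2 to compound 3 (0.18 log units; that floor lies within the scatter), where 4-chlorophenyl rather than 3-chlorophenyl entered at the same place; that step is small, and the limit of > 50000 nM in this assay, at which 2 of the 3 values shown sit, shows how little the values so far separate. Compound 4 is therefore expected to shift by an at least 1.4-fold lower number from compound 2 to compound 4 (0.15 log units; that floor lies within the scatter), toward lower numbers if at all. Compound 4 is estimated at 35000 nM, within 12000 nM to 100000 nM.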

Compound 4, half-maximal inhibitory concentration: > 50000 nM
Compound 4: a limit, no number (the forecaster's own chance of this, stated with the estimate: 45%); middle value at least 1.4-fold (0.15 log units) away from the limit.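

With 3-chlorophenyl in place of 4-chlorophenyl on the nitrogen, the read-out shows an at least 1.5-fold higher number from compound 3 to compound 4 (0.18 log units; that floor lies within the scatter). Any effect of this swap therefore cannot yet be told from scatter, although the true gap could be larger. The step from compound 2 to compound 4 cannot be read, because both values are limits: the limit of > 50000 nM in this assay, at which 3 of the 4 values shown sit.

Going by these compounds, it remains open how far compound 4 really lies from compound 3. Also open, on these data alone, is whether a phenyl carrying a dimethylamino group or a carboxylic acid on this nitrogen would give a clearly lower number.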